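The source may report more compounds than this note shows. Statements on the series, on what has been measured and on what is new or still open speak of the compounds shown alone.

Measured compounds in the series:

compound 1 `CCOC(=O)C[C@H]1[C@@H](O[Si](C)(C)C(C)(C)C)[C@H](n2cnc3c(NC(=O)Nc4ccccc4)ncnc32)O[C@@H]1COC(=O)NC` — 40.4 nM
compound 2 `CNC(=O)NC[C@H]1O[C@@H](n2cnc3c(NC(=O)Nc4ccccc4)ncnc32)[C@H](O[Si](C)(C)C(C)(C)C)[C@@H]1CC(=O)N(C)OC` — 52.7 nM

In a functional assay on SK-OV-3 cells (Homo sapiens) for antiproliferative activity (on this read-out lower numbers stand for stronger inhibition of growth and higher numbers for weaker inhibition of growth), compound 2 gives 52.7 nM, the higher of the two numbers recorded so far. Compound 1 gives 40.4 nM in this assay; the gap between the two lies within the scatter, so the two compounds are not separated by this read-out and neither can be called the stronger.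

Compound 3 `CCOC(=O)C[C@H]1[C@@H](O[Si](C)(C)C(C)(C)C)[C@H](n2cnc3c(NC(=O)Nc4ccccc4)ncnc32)O[C@@H]1CNC(=O)NC` is the next candidate for this assay. Against compound 2 the change is ethoxy in place of methoxy(methyl)amino on a carbonyl carbon, that is methoxy(methyl)carbamoyl to ethoxycarbonyl; the rest of the molecule is kept. Compound 3 thus shares its ethoxycarbonyl with compound 1 and the remainder of its side chain with compound 2. Among the measured compounds shown here, no measured pair isolates this single change, so there is no measured step to lean on.

Given that compound 1 and compound 2 sit within the scatter of each other, the step for compound 3 is expected to be small and within the scatter, with no clear direction, a 1.2-fold lower number from compound 2 to compound 3 (0.07 log units; within the scatter). Compound 3 is accordingly estimated at 45 nM in this assay, with a range from 20 nM to 100 nM.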

Compound 3, concentration for 50% growth inhibition: 21 nM
Estimate against measurement, compound 3: 2.1-fold (0.33 log units) above; low and high end bracket the measured number.
By their numbers in this assay, from the lowest: compounds 3, 1 and 2 (each within the scatter of the next, the first and the last beyond it).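

In this assay, among the compounds shown here, the carbonyl carbon on the saturated chain carbon now has a reading for a single change: ethoxy in place of methoxy(methyl)amino gives a 2.5-fold lower number from compound 2 to compound 3 (0.40 log units; beyond the scatter) and is the first step to clear the scatter, though only modestly. At the other place, (methylcarbamoyl)amino in place of (methylcarbamoyl)oxy on a saturated chain carbon bound to a saturated ring carbon gives a 1.9-fold lower number from compound 1 to compound 3 (0.28 log units; within the scatter) with the ethoxycarbonyl kept, so this exchange does not separate the two compounds on this read-out. No measurement at hand explains the lower number with ethoxycarbonyl at this carbonyl carbon.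

The compounds shown leave open whether a carboxylic acid, a primary amide or a longer ester such as a butyl ester on this carbonyl carbon would stay with ethoxycarbonyl or with methoxy(methyl)carbamoyl on this read-out. They also leave open whether the step from methoxy(methyl)carbamoyl to ethoxycarbonyl carries over to the (methylcarbamoyl)oxy side chain, which appears here only with ethoxycarbonyl.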